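A few compounds are considered here, and "the series" means these few. Any claim that something is new, unique, unknown or untested is made for them only; others in the source may bear on it.

Measured so far:
- compound 1, `CO[C@@H]1[C@@H](OC)[C@H](c2ccccc2)O[C@@H]2CO[C@@H](C3CCCCC3)O[C@@H]12`: 20 ug/mL
- compound 2, `CO[C@@H]1[C@@H](OC)[C@H](c2ccccc2)O[C@@H]2CO[C@@H](Cc3ccccc3)O[C@@H]12`: "not determined" (no result reported)
- compound 3, `CO[C@@H]1[C@@H](OC)[C@H](c2ccccc2)O[C@@H]2CO[C@@H](c3ccc(C)cc3)O[C@@H]12`: "not determined" (no result reported)

These three compounds share one core and differ only in the group carried on the saturated ring carbon that sits between two ring oxygen atoms. In a functional assay on HEL cells (Homo sapiens) for cytotoxicity (a higher number here means that more compound is tolerated, a lower number that less compound is tolerated), compound 1 gives 20 ug/mL. In this assay compound 2 gives "not determined" (no result reported), and compound 3 gives "not determined" (no result reported), so compound 3 stands without any number of its own; only compound 1 gives a point of reference for the whole series.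

Compound 4, `CO[C@@H]1[C@@H](OC)[C@H](c2ccccc2)O[C@@H]2CO[C@@H](c3cccc(Cl)c3)O[C@@H]12`, is the next member. It differs from compound 3 by one change: 3-chlorophenyl in place of 4-methylphenyl on a saturated ring carbon. Going by the values given here, since compound 3 carries no value, no step can be computed, and the expectation for compound 4 rests on compound 1 alone. Both groups exchanged here are of the same size and belong to the same class of six-membered aromatic rings, so a change of cytotoxic tolerance no larger than the usual scatter is expected. The minimum cytotoxic concentration of compound 4 in this assay is estimated at 20 ug/mL, with a range from 7 ug/mL to 60 ug/mL.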

Compound 4, minimum cytotoxic concentration: >= 40 ug/mL
Compound 4: a limit, no number; the forecaster's own chance of this, stated with the estimate: 30%; at least 2.0-fold (0.30 log units) between middle value and limit.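

In this assay compound 4 gives >= 40 ug/mL as a limit of the assay and not a number. Putting 3-chlorophenyl in place of cyclohexyl on this saturated ring carbon gives an at least 2.0-fold higher number from compound 1 to compound 4 (0.30 log units; that floor lies within the scatter) and so shows that an aromatic ring carrying chlorine can stand here with no sign of lower tolerance, although the floor of that step does not separate the two compounds. Going by these compounds alone, this is the first reading for an aromatic group at this position, and it bounds the result on one side only: the limit of >= 40 ug/mL in this assay, at which 1 of the 4 values shown sits.

Going by these compounds, the steps involving compound 2 and compound 3 cannot be read, and how much compound is tolerated beyond the limit of compound 4 stays open. Also open, on these data alone, is how an amine or a carboxylic acid on this ring carbon would fare.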